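The source may hold more compounds than are shown below. What is called first, only, known or untested is meant among the compounds shown, and "the series" means these compounds.

Measured in a functional assay (MiaPaCa cells, Homo sapiens) for inhibition, read by sulforhodamine B assay, with a stated time of 48 h; on this read-out lower numbers stand for stronger inhibition of growth and higher numbers for weaker inhibition of growth:
Compound 1 `O=C(N/N=C/C1=C(Cl)c2ccccc2CCC1)c1cccc(Cl)c1` gives 78400 nM.
Compound 2 `Cc1cc2c(cc1C)C(Cl)=C(/C=N/NC(=O)c1ccccc1)CCC2` gives only a limit of the assay, > 100000 nM.
Compound 3 `COc1cccc(C(=O)N/N=C/C2=C(Cl)c3cc(C)c(C)cc3CCC2)c1C` gives 2000 nM.

Among these numbers compound 3 stands lowest. The nearest number is that of compound 1, which is far higher. Compound 2 contributes no number at all, only a limit (the limit of > 100000 nM in this assay, at which 1 of the 3 values shown sits). Among the compounds with values here, the single step measured between compounds that differ in one place, an at least 50-fold lower number from compound 2 to compound 3 (1.69 log units; beyond the scatter), is large and lies well beyond the scatter.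

Compound 4 `Cc1cc2c(cc1C)C(Cl)=C(/C=N/NC(=O)c1ccccc1N)CCC2` differs from compound 3 in one place: 2-aminophenyl in place of 3-methoxy-2-methylphenyl on a carbonyl carbon. Within the data shown here, only the step from compound 2 to compound 3 bears on this change, and it does so loosely: it shows that the group on the carbonyl carbon can move the number in this assay by a great deal, but it concerns a different pair of groups, and no measured pair shows what a 2-aminophenyl does at this position. Compound 4 is therefore expected to sit higher than compound 3, by a 10-fold higher number from compound 3 to compound 4 (1.00 log units; beyond the scatter), with wide uncertainty. The estimate for compound 4 in this assay is 20000 nM, with a range from 3000 nM to 100000 nM.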

Compound 4, concentration for 50% growth inhibition: 810 nM
Beside the measured number, compound 4's estimate is 25-fold (1.39 log units) above it; measured number outside the range, below it.
By their numbers in this assay, from the lowest: compound 4; then compound 3; then compound 1. At a limit, above all of these: compound 2.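

In this assay, within the data shown here, a single amino in place of hydrogen on an aromatic carbon gives an at least 120-fold lower number from compound 2 to compound 4 (2.09 log units; beyond the scatter), so one added group on the phenyl is enough to bring the number well clear of where compound 2 stands, a change that the earlier compounds could not isolate. The value of compound 2 is a limit, so this step has no exact size: the limit of > 100000 nM in this assay, at which 1 of the 4 values shown sits. The 2-aminophenyl also goes beyond the 3-methoxy-2-methylphenyl, with a 2.5-fold lower number from compound 3 to compound 4 (0.39 log units; beyond the scatter), which shows that on this carbonyl carbon neither the methoxy nor the methyl group is needed for a low number, and that a group with fewer heavy atoms can do modestly better.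

The compounds shown leave open whether a hydroxyl, a methylamino or an acetamido group in place of the amino would serve as well, and whether the amino would give a similar number elsewhere on the phenyl. They also leave open whether the 2-aminophenyl would lower the number in the same way on the core of compound 1, which lacks the two methyl groups.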